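This account rests on a few compounds, and the source may have more. Where it says the series, first, only, none or still open, it means among the compounds named here.

Measured so far in an assay on isolated protein for binding affinity to 5-hydroxytryptamine receptor 1F (Homo sapiens), read by radioligand binding; a lower number here means a stronger inhibitor, a higher number a weaker inhibitor:
compound 1 `CN1CCC(C(=O)c2cccc(NC(=O)c3ccc(F)cc3)c2)CC1`: 5.1 nM
compound 2 `CN1CCC(C(=O)c2cccc(NC(=O)c3ccc(F)cc3)c2O)CC1`: 1100 nM
compound 3 `CN1CCC(C(=O)c2cccc(NC(=O)c3ccc(F)cc3)c2Cl)CC1`: 1700 nM

Compound 1 holds the lowest number of the three; its nearest neighbour is compound 2 and the furthest is compound 3. Both changes to the core ring of compound 1 cost a great deal: a 220-fold higher number from compound 1 to compound 2 (2.33 log units; beyond the scatter), and a 330-fold higher number from compound 1 to compound 3 (2.52 log units; beyond the scatter). Between the two substituted compounds the difference is small, a 1.5-fold higher number from compound 2 to compound 3 (0.19 log units; within the scatter).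

Compound 4 `CN1CCC(C(=O)c2cc(F)cc(NC(=O)c3ccc(F)cc3)c2)CC1` carries the change (fluoro in place of hydrogen on an aromatic carbon). For the measured compounds named here, no measured step tests this change directly; the two steps that bear on it, from compound 1 to compound 2 and to compound 3, both show that substitution on this ring of the core can be heavily penalised. A loss is therefore expected for compound 4, though a smaller one, given that fluoro is a single heavy atom. For compound 4 the expected step is a 3.5-fold higher number from compound 1 to compound 4 (0.55 log units; beyond the scatter). Compound 4 is estimated at 18 nM, with an expected range of 4 nM to 80 nM.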

Compound 4, inhibition constant: 41 nM
Compound 4: middle estimate off by 2.3-fold (0.36 log units), on the low side, and the stated range covers the measured number.
By their numbers in this assay, from the lowest: compound 1; then compound 4; then compounds 2 and 3 (each within the scatter of the next).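

In this assay, the change brings an 8.0-fold higher number from compound 1 to compound 4 (0.91 log units; beyond the scatter) with fluoro on this aromatic carbon, meta to a group of 9 heavy atoms and meta to a large group. Even this single added fluorine costs a modest step beyond the scatter, so this place on the shared core is not free of penalty. Nothing measured here accounts for the loss.

Still open, from the compounds shown here alone, is how a methyl, a methoxy or an amine on this same carbon would compare with fluoro. Also open, going by these compounds, is whether the step grows with the size of the entering group.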